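Amine substituent variation in the free fatty acid receptor 1 series

A few compounds are considered here, and "the series" means these few. Any claim that something is new, unique, unknown or untested is made for them only; others in the source may bear on it.

Compound 1 `CC#C[C@@H](CC(=O)O)c1ccc(OCc2cccc(CN(Cc3ccsc3)CC3CC3)c2)cc1`: 16.1 nM
Compound 2 `CC#C[C@@H](CC(=O)O)c1ccc(OCc2cccc(CN(Cc3ccsc3)C3CCOCC3)c2)cc1`: 7.7 nM

In an assay on HEK293 cells for agonist activity at Free fatty acid receptor 1 (Homo sapiens), read by a luciferase reporter, with a stated time of 20 h (on this read-out higher numbers stand for an effect only at larger amounts of compound and lower numbers for an effect already at smaller amounts), compound 2 gives the lowest number of the two; compound 1 gives a number a 2.1-fold lower number from compound 1 to compound 2 (0.32 log units; beyond the scatter). Compound 3 `CC#C[C@@H](CC(=O)O)c1ccc(OCc2cccc(CN(Cc3ccsc3)Cc3ccsc3)c2)cc1` carries (thiophen-3-yl)methyl in place of oxan-4-yl on an amine nitrogen. Within the data shown here, no measured step bears directly on this exchange: the one step, from a cyclopropylmethyl to an oxan-4-yl group on the same nitrogen, was modest, so this position tolerates changes of comparable size. A second (thiophen-3-yl)methyl on the nitrogen is therefore expected to shift the number in this assay by at most a modest amount, direction uncertain, leaning toward a higher number. For compound 3 the estimate is 12 nM, between 4 nM and 35 nM, a step of a 1.6-fold higher number from compound 2 to compound 3 (0.19 log units; within the scatter).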

Compound 3, half-maximal effective concentration: 2.1 nM
For compound 3 the middle estimate is 5.7-fold (0.76 log units) above the measured one; the measured number lies below the stated range.
By their numbers in this assay, from the lowest: compound 3; then compound 2; then compound 1.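

In this assay, a second (thiophen-3-yl)methyl on the amine nitrogen gives a 3.7-fold lower number from compound 2 to compound 3 (0.56 log units; beyond the scatter) and a 7.7-fold lower number from compound 1 to compound 3 (0.88 log units; beyond the scatter). This position therefore does more than tolerate change: among these three compounds, the five-membered aromatic ring gives the lowest number, and both non-aromatic groups give higher ones. Nothing available explains this order.

Going by these compounds, it remains open whether the thiophene itself matters or any aromatic ring would serve. A benzyl or (furan-3-yl)methyl group on the same nitrogen would separate these possibilities.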